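Sulfonyl aryl variants on the shared core

A few compounds are considered here, and "the series" means these few. Any claim that something is new, unique, unknown or untested is made for them only; others in the source may bear on it.

Compound 1 `O=S(=O)(Nc1ccc2oc(-c3ccccc3)nc2c1)c1ccc(Cl)cc1` is tested in an assay on isolated protein for inhibition of malate dehydrogenase, mitochondrial (Sus scrofa), with stated times of 45 min and 30 min; on this read-out lower numbers stand for stronger inhibition and higher numbers for weaker inhibition. In this assay compound 1 gives only a limit, > 63000 nM. Compound 2 `O=S(=O)(Nc1ccc2oc(-c3ccccc3)nc2c1)c1cccc(O)c1` likewise gives in this assay only a limit, > 63000 nM. Compound 3 `COc1ccc(Cl)cc1S(=O)(=O)Nc1ccc2oc(-c3ccccc3)nc2c1` gives in this assay only a limit, > 63000 nM. Compound 1 thus stands at the limit of > 63000 nM in this assay, at which 3 of the 3 values shown sit, and no number separates it from compound 2 or compound 3. Compound 4 `O=S(=O)(Nc1ccc2oc(-c3ccccc3)nc2c1)c1ccc(C(F)(F)F)cc1` is not yet measured in this assay; it differs from compound 1 by trifluoromethyl in place of chloro on an aromatic carbon. The measured steps that alter the same aryl group on the sulfonyl sulfur are a step that the two limits leave unreadable from compound 1 to compound 2, a step that the two limits leave unreadable from compound 1 to compound 3 and a step that the two limits leave unreadable from compound 2 to compound 3, none of them readable in size because all three compounds sit at the limit of > 63000 nM in this assay, at which 3 of the 3 values shown sit. Changes on this aryl group have so far given no sign of moving the read-out off the limit, and for compound 4 a step that the limit leaves unreadable from compound 1 to compound 4 is expected, most likely again reported as a limit. Compound 4 is estimated at 100000 nM, between 30000 nM and 300000 nM.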

Compound 4, half-maximal inhibitory concentration: > 63000 nM
Compound 4 gave a limit, no number; the forecaster's own chance of this, stated with the estimate: 85%; the middle value does not contradict the limit.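

Compound 1 and compound 4 both give only limits in this assay, and no size can be read for the step between them. The compounds shown leave open whether any change on the aryl group on the sulfonyl sulfur gives a measurable inhibition, all resting at one value: the limit of > 63000 nM in this assay, at which 4 of the 4 values shown sit.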